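The source may report more compounds than this note shows. Statements on the series, on what has been measured and on what is new or still open speak of the compounds shown alone.

Working notes on the series. In a functional assay on the whole organism (strain Wistar) with Rattus norvegicus as the target, with a stated time of 15 days, at a dose of 100 mg/kg by the oral route (a higher number here means a stronger effect of the compound at the dose given, a lower number a weaker effect), compound 1 `O=C1NC(=O)/C(=C/c2ccc(OCCSc3nnc(-c4ccccc4[N+](=O)[O-])[nH]3)cc2)S1` gives 49.1%. Among the measured compounds shown here, compound 2 `O=C1NC(=O)/C(=C/c2ccc(OCCSc3nnc(Cc4ccccc4)o3)cc2)S1` holds the lower of the two numbers measured so far; in this assay compound 2 gives 34.6%, a number that sits below that of compound 1 by a gap beyond the usual scatter. For the measured compounds named here, compound 1 and compound 2 differ in more than one place, so no single step between them can be read from these two values.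

Compound 3 `O=C1NC(=O)/C(=C/c2ccc(OCCSc3nnc(-c4ccncc4)o3)cc2)S1` has not yet been measured. It differs from compound 2 by one change: pyridin-4-yl in place of benzyl on an aromatic carbon. Going by the values given here, no step between measured compounds covers this change, so the expectation rests only on the two numbers in hand and on the change itself. The step expected is a number 5.4 percentage points higher from compound 2 to compound 3 (within the scatter), a small rise that may well stay within the scatter. Compound 3 is estimated to give 40% in this assay, with a range from 25% to 55%.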

Compound 3, a percentage reported as activity, at one dose (the size of the read-out at that dose, not a potency): 69.7%
Compound 3: middle estimate off by 29.7 percentage points, on the low side; measured number above the stated range.
By their numbers in this assay, from the lowest: compound 2; then compound 1; then compound 3.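

On the aromatic carbon of the five-membered aromatic ring with 2 nitrogen and 1 oxygen, pyridin-4-yl in place of benzyl gives a number 35.1 percentage points higher from compound 2 to compound 3 (beyond the scatter) in this assay. Among the compounds shown here, this is the first single-change step, and it shows that the number in this assay depends strongly on the group at this position. The change alters two things at once, a ring of carbon only becoming a ring with 1 hetero atom and 7 heavy atoms becoming 6, and nothing at hand accounts for the step or assigns it to either difference.

Open, from the compounds shown here alone, is whether phenyl at this position would stay near benzyl or near pyridin-4-yl, which would separate the ring nitrogen from the heavy-atom change. Open too, going by these compounds, is whether pyridin-3-yl or an amine-bearing phenyl would keep the higher number.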